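Chain-end variation on a shared core: two measured, one pending

The source may report more compounds than this note shows. Statements on the series, on what has been measured and on what is new or still open speak of the compounds shown alone.

Measured compounds:
compound 1, `c1ccc(COc2ccc(OCCOCCNc3ccncc3)cc2)cc1` — 20600 nM
compound 2, `COc1cc(OCCOCCNC2CCCC2)ccc1OCc1ccccc1` — 44600 nM

In a functional assay on SK-OV-3 cells (Homo sapiens) for inhibition, read by CCK-8 assay, with a stated time of 70 h (a lower number here means a stronger inhibitor, a higher number a weaker inhibitor), compound 1 gives 20600 nM and compound 2 gives 44600 nM. Compound 1 stands at the lower of the two numbers; compound 2 sits at a higher number, and the gap between them is beyond the usual scatter. Within the data shown here, no pair among the measured compounds differs in a single place, so no step can be read from them directly, and both numbers sit far up the weak end of this assay.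

Compound 3, `OCCOCCOCCOc1ccc(OCc2ccccc2)cc1`, is the next compound to be measured. It differs from compound 1 in one place:

2-hydroxyethoxy in place of (pyridin-4-yl)amino on a saturated chain carbon, two bonds along the chain from an oxygen on a saturated carbon

The chain end of compound 1 is thus exchanged for an open, ring-free terminus, while the shared core and the ether chain leading to it are kept. Among the measured compounds shown here, with no measured step of this kind available, the expectation rests only on compound 1 and its value 20600 nM. Compound 3 is expected to come in at a somewhat higher number than compound 1, with the step from compound 1 to compound 3 estimated as a 1.9-fold higher number from compound 1 to compound 3 (0.29 log units; within the scatter), a modest move toward weaker inhibition that may not clear the scatter. For compound 3 the estimate in this assay is 40000 nM, within a range from 15000 nM to 110000 nM.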

Compound 3, half-maximal inhibitory concentration: 59400 nM
Compound 3: middle estimate off by 1.5-fold (0.17 log units), on the low side; measured number inside the range.
By their numbers in this assay, from the lowest: compound 1; then compounds 2 and 3 (each within the scatter of the next).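

In this assay, among these compounds, putting 2-hydroxyethoxy in place of (pyridin-4-yl)amino on a saturated chain carbon, two bonds along the chain from an oxygen on a saturated carbon, gives a 2.9-fold higher number from compound 1 to compound 3 (0.46 log units; beyond the scatter) and is the first step that can be read directly, since the two earlier compounds differ in more than one place. This shows that the number responds to the chain end, and that the (pyridin-4-yl)amino end of compound 1 gives the lower number of this pair, although the two groups match in their counts of hydrogen-bond donors and acceptors and differ in the ring, the nitrogen atoms and the heavy-atom count. No measurement at hand gives a reason for the step.

One step cannot show whether the difference follows the pyridine ring or the amino nitrogen, and a phenylamino or plain dimethylamino end on the same chain would separate the two. Steps involving compound 2 cannot be read, so the effect of its cyclopentylamino end remains open, as does that of a carboxylic acid end or a longer chain.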